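Methylamino to ethylamino on the shared core

This account rests on a few compounds, and the source may have more. Where it says the series, first, only, none or still open, it means among the compounds named here.

Measured in a functional assay on HCT-8 cells (Homo sapiens) for antiproliferative activity, read by MTT assay, with a stated time of 48 h; a higher number here means a weaker inhibitor, a lower number a stronger inhibitor:
- compound 1 `C=C(c1ccc(OC)cc1NC(=O)CO)c1ccc(OC)c2c1OC(C)(C)C=C2`: 130 nM
- compound 2 `C=C(c1ccc(OC)cc1NC(=O)CNC)c1ccc(OC)c2c1OC(C)(C)C=C2`: 320 nM

Of the two, compound 2, at 320 nM, has the higher number and is the weaker inhibitor. Compound 3 `C=C(c1ccc(OC)cc1NC(=O)CNCC)c1ccc(OC)c2c1OC(C)(C)C=C2` departs from it by a single change: methyl in place of hydrogen on a saturated chain carbon bound to an amine nitrogen. This places methyl in place of hydrogen on a saturated chain carbon bound to an amine nitrogen, turning methylamino to ethylamino.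

Among the compounds with values here, only one measured step bears on this, and only loosely: a 2.5-fold higher number from compound 1 to compound 2 (0.39 log units; beyond the scatter), a modest step that brought in methylamino in place of hydroxy. Within the data shown here, no measured pair tests the methyl change itself, so that step serves only as a guide to size. In this assay little movement is therefore expected, and the estimated change, a 1.2-fold higher number from compound 2 to compound 3 (0.07 log units; within the scatter), is slightly upward. Compound 3 is expected at 380 nM, with an estimated range of 150 nM to 900 nM.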

Compound 3, half-maximal inhibitory concentration: 1380 nM
For compound 3 the middle estimate is 3.6-fold (0.56 log units) below the measured one; the whole stated range lies below it.
By their numbers in this assay, from the lowest: compound 1; then compound 2; then compound 3.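

In this assay, adding a single methyl to turn methylamino to ethylamino gave a 4.3-fold higher number from compound 2 to compound 3 (0.63 log units; beyond the scatter), which shows that this saturated chain carbon bound to an amine nitrogen is not a silent place: one extra carbon on the amine is enough to move the number beyond the scatter. Measured from the hydroxy compound, the replacement now reads as an 11-fold higher number from compound 1 to compound 3 (1.03 log units; beyond the scatter), so both steps run the same way and compound 3 is the weakest inhibitor of the three. Nothing at hand accounts for this shift. On these data alone, whether the number would keep rising with a longer chain such as propylamino remains open. So does what a plain primary amine or a dimethylamino group would give on the shared core.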